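Pyridazinone to pyrimidinone isomer swap: solubility working notes

A few compounds are considered here, and "the series" means these few. Any claim that something is new, unique, unknown or untested is made for them only; others in the source may bear on it.

Measured in a physicochemical assay for solubility, in phosphate buffer, at pH 7.4; a higher number here means a more soluble compound, a lower number a less soluble compound:
- compound 1 `COc1cc(F)ccc1-c1ccnc2[nH]c(C3CCN(CC(=O)N(C)C)CC3)cc12`: 38000 nM
- compound 2 `CC(C)n1nc(-c2ccnc3[nH]c(C4CCN(CC(=O)N(C)C)CC4)cc23)ccc1=O`: 11000 nM

Compound 2 holds the lower of the two numbers in this assay. For the measured compounds named here, the only measured step, a 3.5-fold lower number from compound 1 to compound 2 (0.54 log units; beyond the scatter), is modest and lies beyond the scatter.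

Not yet measured is compound 3 `CC(C)n1cc(-c2ccnc3[nH]c(C4CCN(CC(=O)N(C)C)CC4)cc23)cnc1=O`, which has the same atoms as compound 2, joined differently: a group of 10 heavy atoms (7 carbon, 2 nitrogen, 1 oxygen; one six-membered aromatic ring with 2 hetero atoms) in place of a group of 10 heavy atoms (7 carbon, 2 nitrogen, 1 oxygen; one six-membered aromatic ring with 2 hetero atoms), on an aromatic carbon. The exchanged group sits on the same aromatic carbon of the shared core, opposite the ring nitrogen. Each group has one six-membered aromatic ring with 2 hetero atoms.

Going by the values given here, no measured pair tests a change of this kind. The step to compound 2 bears on it only loosely, as a guide to how far one exchange of aromatic group has moved the number in this series, namely a 3.5-fold lower number from compound 1 to compound 2 (0.54 log units; beyond the scatter). A smaller move is expected here, with no clear direction and nothing beyond the scatter. The expected step is a 1.2-fold higher number from compound 2 to compound 3 (0.07 log units; within the scatter).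

For compound 3 the estimated value is 13000 nM, with an expected range of 4500 nM to 38000 nM.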

Compound 3, solubility: 910000 nM
Beside the measured number, compound 3's estimate is 70-fold (1.85 log units) below it; the whole stated range lies below it.
By their numbers in this assay, from the lowest: compound 2; then compound 1; then compound 3.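

In this assay, this aromatic carbon, opposite the ring nitrogen, proves far more sensitive to the arrangement of the attached ring than the earlier pair could show: the two groups match in heavy atoms, hydrogen-bond donors and acceptors and net charge, yet joining the same atoms differently gives an 83-fold higher number from compound 2 to compound 3 (1.92 log units; beyond the scatter) and places compound 3 at the top of the three numbers. Replacing the carbon-only aromatic ring with a ring having 2 hetero atoms also has no fixed direction in this small set, as a 24-fold higher number from compound 1 to compound 3 (1.38 log units; beyond the scatter) runs opposite to the earlier lower step to compound 2, so compound 2 goes against any simple rule based on ring type. No supporting measurement is available to account for the size of this jump.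

Only one pair of ring arrangements is shown, both with the same isopropyl group, so it remains open whether the large step would persist with an amine or a carboxylic acid in that group's place. Going by these compounds, it also remains open how compound 3 compares with compound 2 on any read-out other than this assay.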